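A few compounds are considered here, and "the series" means these few. Any claim that something is new, unique, unknown or untested is made for them only; others in the source may bear on it.

Compound 1 `CCN1CCCC1CNC(=O)c1cc(NS(=O)(=O)N(C)C)c(Cl)cc1OC` in a functional assay on the whole organism for inhibition, with Mus musculus as the target (on this read-out higher numbers stand for an effect only at larger amounts of compound and lower numbers for an effect already at smaller amounts), gives 8.3 mg/kg. Compound 3 `CCN1CCCC1CNC(=O)c1cc(NS(=O)(=O)NC)c(Cl)cc1OC` reaches only a limit of the assay in this assay, > 50 mg/kg. The change hydrogen in place of methyl on a sulfonamide nitrogen therefore produced an at least 6.0-fold higher number from compound 1 to compound 3 (0.77 log units; beyond the scatter), readable only as a bound because of the limit of > 50 mg/kg in this assay, at which 2 of the 3 values shown sit. Compound 2 `CCN1CCCC1CNC(=O)c1cc(NS(=O)(=O)NC)ccc1OC` likewise gives only a limit in this assay, > 50 mg/kg. The step that the two limits leave unreadable from compound 2 to compound 3 stays unreadable because of the limit of > 50 mg/kg in this assay, at which 2 of the 3 values shown sit. The difference between the core of compound 1 and the core of compound 2 is not broken down here. Compound 4 `CCN1CCCC1CNC(=O)c1cc(NS(N)(=O)=O)ccc1OC` is still to be measured in this assay. Among the measured compounds shown here, it differs from compound 2 by hydrogen in place of methyl on a sulfonamide nitrogen, the same kind of change as from compound 1 to compound 3, though there the nitrogen also carried a saturated chain carbon, whereas here its only other neighbour is the sulfonyl sulfur. Given that step and the limit at which compound 2 sits, compound 4 is expected to give 80 mg/kg in this assay, within 30 mg/kg to 300 mg/kg. The step this estimate implies is a step that the limit leaves unreadable from compound 2 to compound 4, most likely again ending at a limit.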

Compound 4, dose for half-maximal effect: > 50 mg/kg
Compound 4: no number, only a limit; the forecaster's own chance of this, stated with the estimate: 85%; the middle value lies beyond the limit too.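

No new step can be read between compound 2 and compound 4, as both give only a limit: the limit of > 50 mg/kg in this assay, at which 3 of the 4 values shown sit. The compounds shown leave open whether hydrogen in place of methyl on this sulfonamide nitrogen shifts the dose at all.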